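The compounds below may be only part of what the source reports. "The series", "measured", "known", "first", "only" and "open" are said of these compounds alone.

Values in a functional assay on U-251 cells (Homo sapiens) for antiproliferative activity, read by MTT assay, with a stated time of 72 h (on this read-out lower numbers stand for stronger inhibition and higher numbers for weaker inhibition), follow:
- Compound 1 `O=C(Nc1ccc(Cl)c(-c2nnc3c(Cl)cccn23)c1)c1ccc(C(F)(F)F)cc1Cl` gives > 100000 nM as a limit of the assay
- Compound 2 `O=C(Nc1ccc(Cl)c(-c2nnc3c(Cl)cccn23)c1)c1ccccn1` gives 79000 nM as a measured number
- Compound 3 `O=C(Nc1ccc(Cl)c(-c2nnc3c(Cl)cccn23)c1)c1cccnc1` gives > 100000 nM as a limit of the assay

Compound 3 has no measured number and stands at the limit of > 100000 nM in this assay, at which 2 of the 3 values shown sit, in this series. Going by the values given here, only compound 2 gives a number so far.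

The next compound is compound 4 `O=C(Nc1ccc(Cl)c(-c2nnc3c(Cl)cccn23)c1)c1c(F)cccc1Cl`, and the change from compound 3 is 2-chloro-6-fluorophenyl in place of pyridin-3-yl on a carbonyl carbon with 2-chloro-6-fluorophenyl in place of pyridin-3-yl on a carbonyl carbon.

Among the compounds with values here, one measured step bears directly on this place. It is an at least 1.2-fold higher number from compound 2 to compound 3 (0.10 log units; that floor lies within the scatter) and concerns pyridin-3-yl in place of pyridin-2-yl on a carbonyl carbon. That step gives no size beyond the scatter, and it only exchanges one pyridine for another. Compound 1 also has a ring of carbon only on that carbonyl carbon and shows > 100000 nM as a limit of the assay.

On these grounds, an expected a number no higher from compound 3 to compound 4 (the limit leaves the size open) in this assay is estimated, which means no step beyond the scatter in either direction. Compound 4 is estimated at 100000 nM with an expected range from 40000 nM to 200000 nM, and a limit of the assay is the likely expectation.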

Compound 4, half-maximal inhibitory concentration: > 100000 nM
Compound 4 was reported as a limit (the forecaster's own chance of this, stated with the estimate: 60%); the middle value sits exactly at the limit.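

In this assay, 2-chloro-6-fluorophenyl on the carbonyl carbon gives no measured number, so a second substituted ring of carbon only, after that of compound 1, ends at a limit of the assay. Against compound 2, the only compound with a number, the change gives an at least 1.2-fold higher number from compound 2 to compound 4 (0.10 log units; that floor lies within the scatter), so no size beyond the scatter can be stated, and the step between compound 3 and compound 4 cannot be read, as both values are limits. Across pyridine and substituted phenyl groups at this place, the series so far rests almost entirely at one limit, with compound 2 the one exception in giving a number: the limit of > 100000 nM in this assay, at which 3 of the 4 values shown sit.

The compounds shown leave open whether a non-aromatic group on the carbonyl carbon, such as morpholine or a short alkyl chain, would give a number clear of the limit. They also leave open whether a change in the shared core, such as an amine in place of a chlorine, would bring the series into the measurable range.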